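The source may report more compounds than this note shows. Statements on the series, on what has been measured and on what is new or still open speak of the compounds shown alone.

Working notes on the series. Compound 2 `O=C(c1ccc2c(c1)OCCO2)C1CCN(Cc2coc(-c3ccc(C(F)(F)F)cc3)n2)CC1` is known in an ADME assay on HEK293 cells (Homo sapiens) for cytotoxicity, read by MTT assay, with a stated time of 36 h (a lower number here means a stronger inhibitor, a higher number a weaker inhibitor), only as a limit: compound 2 gives > 150 ug/mL, which is a limit of the assay and not a number. Compound 1 `O=C(c1ccc2c(c1)OCCO2)C1CCN(Cc2coc(-c3ccc(Cl)cc3)n2)CC1` stands in the same position; in this assay compound 1 gives > 150 ug/mL, again a limit. Within the data shown here, the one measured step, a step that the two limits leave unreadable from compound 1 to compound 2, is accordingly unreadable, and the only evidence is the limit of > 150 ug/mL in this assay, at which 2 of the 2 values shown sit. Compound 3 `O=C(c1ccc2c(c1)OCCO2)C1CCN(Cc2coc(-c3ccccc3F)n2)CC1` differs from compound 2 by 2-fluorophenyl in place of 4-(trifluoromethyl)phenyl on an aromatic carbon. Among the measured compounds shown here, only the step from compound 1 to compound 2 bears on this change, and it leaves no readable size, so no direction beyond the scatter can be expected for compound 3 in this assay. The step that the limit leaves unreadable from compound 2 to compound 3 is estimated to remain within the scatter. Compound 3 is expected to give 180 ug/mL, with a range from 90 ug/mL to 360 ug/mL, most probably reported once more only as a limit.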

Compound 3, half-maximal inhibitory concentration: > 150 ug/mL
Compound 3 gave a limit, no number; the forecaster's own chance of this, stated with the estimate: 80%; the middle value lies beyond the limit too.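

In this assay, compound 1, compound 2 and compound 3 are known only as limits of the assay, so no new step among them can be read: the limit of > 150 ug/mL in this assay, at which 3 of the 3 values shown sit.

The compounds shown leave open whether 4-chlorophenyl, 4-(trifluoromethyl)phenyl and 2-fluorophenyl differ at all in this assay.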